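Three Measured Glycoside Derivatives and One Untested Analogue

The compounds below may be only part of what the source reports. "The series", "measured", "known", "first", "only" and "open" are said of these compounds alone.

Compound 1 `COc1cc(C2=NOC(CO[C@@H]3O[C@H](CSc4ncn[nH]4)[C@H]4OC5(CCCC5)O[C@@H]34)C2)cc(OC)c1OC`: > 100000 nM
Compound 2 `CC1(C)O[C@H]2[C@H](OCc3noc(-c4ccc([N+](=O)[O-])cc4)n3)O[C@H](CO)[C@H]2O1`: 60000 nM
Compound 3 `Cc1ccc(S(=O)(=O)OC[C@H]2O[C@@H](OCc3noc(-c4ccc([N+](=O)[O-])cc4)n3)[C@@H]3OC4(CCCC4)O[C@@H]32)cc1`: > 100000 nM

Of the compounds shown here, three have been tested in a functional assay on SW1573 cells (Homo sapiens) for antiproliferative activity, read by sulforhodamine B assay, with a stated time of 48 h; a lower number here means a stronger inhibitor of growth, a higher number a weaker inhibitor of growth. Compound 2 gives a number, 60000 nM. Compound 1 gives only a limit, > 100000 nM. Compound 3 likewise gives only a limit, > 100000 nM, and so its true value is not known. Compound 3 therefore sits at the weak end of what has been seen, sharing the limit of > 100000 nM in this assay, at which 2 of the 3 values shown sit, with compound 1; only compound 2 returns a number at all, and that number is itself high.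

The untested analogue is compound 4 `Nc1nnc(SC[C@H]2O[C@@H](OCc3noc(-c4ccc([N+](=O)[O-])cc4)n3)[C@@H]3OC4(CCCC4)O[C@@H]32)s1`. It differs from compound 3 by (5-amino-1,3,4-thiadiazol-2-yl)sulfanyl in place of ((4-methylphenyl)sulfonyl)oxy on a saturated chain carbon bound to a saturated ring carbon. From the compounds shown here alone, no comparable single-point change has been measured, so the size of the step is unknown. Compound 1, which also carries a sulfanyl-linked aromatic heterocycle on the same kind of carbon, reaches only the limit, > 100000 nM, and that is the nearest guide.

Compound 4 is therefore expected to remain very weak in this assay, with an estimated step of a number no higher from compound 3 to compound 4 (the limit leaves the size open) that is most likely none beyond the scatter. The estimate for compound 4 is 100000 nM, within a range from 30000 nM to 300000 nM.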

Compound 4, concentration for 50% growth inhibition: 16000 nM
Estimate against measurement, compound 4: 6.3-fold (0.80 log units) above; measured number outside the range, below it.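

In this assay, among these compounds, (5-amino-1,3,4-thiadiazol-2-yl)sulfanyl in place of ((4-methylphenyl)sulfonyl)oxy on a saturated chain carbon bound to a saturated ring carbon gives an at least 6.2-fold lower number from compound 3 to compound 4 (0.79 log units; beyond the scatter), the only step between compounds differing in one place that can be read in this set. Among the compounds shown here, it shows that this position is not silent: the group carried on this carbon can shift growth inhibition beyond the scatter, something the earlier compounds, which differ from one another in more than one place, could not show. The step is a lower bound whose true size stays open, and the value it starts from is not a number but this limit: the limit of > 100000 nM in this assay, at which 2 of the 4 values shown sit.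

The change swaps the linking atoms, the ring and the amino group all at once, so the compounds shown leave open which of these parts accounts for the step. They also leave open whether an acetamide in place of the amino group, or a plain phenylsulfanyl group in place of the whole (5-amino-1,3,4-thiadiazol-2-yl)sulfanyl group, would keep, extend or lose the gain seen in compound 4.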